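Two methyls in place of methoxy on the pyrazoline aryl

A few compounds are considered here, and "the series" means these few. Any claim that something is new, unique, unknown or untested is made for them only; others in the source may bear on it.

Compound 1 `COc1ccc(C2=NN(C3=NC(c4ccccc4)CS3)C(c3cccc4ccccc34)C2)cc1` gives 9510 nM in a functional assay on BGC-823 cells (Homo sapiens) for inhibition, read by CCK-8 assay, with a stated time of 48 h; a lower number here means a stronger inhibitor, a higher number a weaker inhibitor. Compound 2 `Cc1ccc(C2=NN(C3=NC(c4ccccc4)CS3)C(c3ccc4ccccc4c3)C2)cc1` gives 8940 nM. Compound 3 `COc1ccc(C2=NN(C3=NC(c4ccccc4)CS3)C(c3ccc4ccccc4c3)C2)cc1` gives 7250 nM.

Compound 1 has the highest number of the three, yet its gaps to compound 2 and compound 3 lie within the scatter, so no order among them can be claimed. Compound 4 `Cc1ccc(C2=NN(C3=NC(c4ccccc4)CS3)C(c3cccc4ccccc34)C2)cc1C` differs from compound 1 in one place: 3,4-dimethylphenyl in place of 4-methoxyphenyl on a carbon with a double bond to nitrogen. The step that bears on this is the swap of methoxy for methyl, a 1.2-fold lower number from compound 2 to compound 3 (0.09 log units; within the scatter), a change too small to count. Among the compounds with values here, the second methyl has no measured counterpart here. A step near zero is therefore expected, a 1.1-fold lower number from compound 1 to compound 4 (0.02 log units; within the scatter), and compound 4 is estimated at 9000 nM, with a range from 4000 nM to 20000 nM.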

Compound 4, half-maximal inhibitory concentration: 8460 nM
Compound 4: the middle estimate sits 1.1-fold (0.03 log units) above what was measured; the measured number falls inside the stated range.
By their numbers in this assay, from the lowest: compounds 3, 4, 2 and 1 (each within the scatter of the next).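

In this assay, 3,4-dimethylphenyl in place of 4-methoxyphenyl gives a 1.1-fold lower number from compound 1 to compound 4 (0.05 log units; within the scatter), so losing the oxygen with its hydrogen-bond acceptor and gaining a second methyl leaves no readable change at this position. The earlier methoxy and methyl comparison came only from compounds carrying naphthalen-2-yl, and this step extends the same flat picture to a compound carrying naphthalen-1-yl. No evidence is available to explain this result. Still open, on these data alone, is whether any group at this position can move the number beyond the scatter. A phenyl carrying an amine or a carboxylic acid would test that.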